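The source may hold more compounds than are shown below. What is called first, only, known or untested is meant among the compounds shown, and "the series" means these compounds.

Compounds measured so far:
- compound 1, `Brc1ccc(-c2nnc(Nc3ccccc3)s2)cc1`: 40200 nM
- compound 2, `Cc1ccc(Nc2nnc(-c3ccc(C)cc3C)s2)cc1`: 34300 nM
- compound 3, `Cc1ccc(Nc2nnc(-c3ccc(Br)cc3)s2)cc1`: 28600 nM

In an assay on isolated protein for inhibition of beta-glucuronidase (Bos taurus), read by spectrophotometry, with a stated time of 30 min (a higher number here means a weaker inhibitor, a lower number a stronger inhibitor), the three numbers sit close together. Compound 1 gives the largest of them, but its gaps to compound 2 and compound 3 both lie within the scatter, so no order among them can be claimed. Compound 4, `Brc1ccc(-c2nnc(Nc3cccc(Br)c3)s2)cc1`, differs from compound 1 in one place: bromo in place of hydrogen on an aromatic carbon. Within the data shown here, the only measured step of a comparable kind is a 1.4-fold lower number from compound 1 to compound 3 (0.15 log units; within the scatter), which did not move the number beyond the scatter. With that single precedent, a substituent added to the same ring of compound 1 is expected to leave the result in this assay roughly unchanged, with a 1.3-fold lower number from compound 1 to compound 4 (0.13 log units; within the scatter). Compound 4 is therefore estimated at 30000 nM, within 12000 nM to 75000 nM.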

Compound 4, half-maximal inhibitory concentration: 17300 nM
Estimate against measurement, compound 4: 1.7-fold (0.24 log units) above; the measured number falls inside the stated range.
By their numbers in this assay, from the lowest: compounds 4, 3, 2 and 1 (each within the scatter of the next, the first and the last beyond it).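

In this assay, among these compounds, bromo in place of hydrogen on this aromatic carbon, meta to a large group, gives the first step beyond the scatter: a 2.3-fold lower number from compound 1 to compound 4 (0.37 log units; beyond the scatter). The step is modest, but it shows that this ring of compound 1 can take a single heavy atom without any loss, whereas the methyl step, a 1.4-fold lower number from compound 1 to compound 3 (0.15 log units; within the scatter), stayed within the scatter. Nothing shown explains the gain.

The compounds shown leave open whether chloro, methoxy, an amine or a carboxylic acid at this same carbon would give a similar number. They also leave open whether bromo on the other ring of the core of compound 4 would add to the step.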